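The source may hold more compounds than are shown below. What is called first, only, known or untested is meant among the compounds shown, and "the series" means these compounds.

Of the compounds shown here, three built on one shared core have been tested in a functional assay on K562 cells (Homo sapiens) for antiproliferative activity, read by MTT assay, with a stated time of 48 h; a higher number here means a weaker inhibitor, a lower number a stronger inhibitor. Compound 1 `Cn1c(N)c(-c2nc3ccccc3[nH]2)c2nc(C#N)c(C#N)nc21` reaches only the assay's limit, > 50000 nM. Compound 2 `CN(C)CCn1c(N)c(-c2nc3ccccc3[nH]2)c2nc(C#N)c(C#N)nc21` gives 6340 nM, and compound 3 `CN1CCN(CCCn2c(N)c(-c3nc4ccccc4[nH]3)c3nc(C#N)c(C#N)nc32)CC1` gives 1260 nM. Of the two numbers, compound 2 stands highest, and its nearest neighbour is reached by the step of a 5.0-fold lower number from compound 2 to compound 3 (0.70 log units; beyond the scatter). Compound 4 `N#Cc1nc2c(-c3nc4ccccc4[nH]3)c(N)n(CCCN3CCCCC3)c2nc1C#N` is not yet measured; it differs from compound 2 by (piperidin-1-yl)methyl in place of dimethylamino on a saturated chain carbon, two bonds along the chain from an aromatic nitrogen. Within the data shown here, the step that bears most on this change is the one from compound 2 to compound 3, where (4-methylpiperazin-1-yl)methyl replaced dimethylamino; the steps of an at least 7.8-fold lower number from compound 1 to compound 2 (0.89 log units; beyond the scatter) and an at least 39-fold lower number from compound 1 to compound 3 (1.59 log units; beyond the scatter) point the same way. A modest lowering is therefore expected: a 4.2-fold lower number from compound 2 to compound 4 (0.63 log units; beyond the scatter). Compound 4 is estimated at 1500 nM, between 500 nM and 5000 nM.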

Compound 4, half-maximal inhibitory concentration: 3460 nM
Estimate against measurement, compound 4: 2.3-fold (0.36 log units) below; measured number inside the range.
By their numbers in this assay, from the lowest: compound 3; then compounds 4 and 2 (each within the scatter of the next). At a limit, above all of these: compound 1.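

Moving from 2-(dimethylamino)ethyl to 3-(piperidin-1-yl)propyl makes no change that stands clear of the scatter (a 1.8-fold lower number from compound 2 to compound 4 (0.26 log units; within the scatter)). The group at the chain end still counts, since piperidin-1-yl and 4-methylpiperazin-1-yl on the same chain do differ (a 2.7-fold higher number from compound 3 to compound 4 (0.44 log units; beyond the scatter)). The gain over the methyl group of compound 1 is large (an at least 14-fold lower number from compound 1 to compound 4 (1.15 log units; beyond the scatter)), but that step rests on a limit, not a number: the limit of > 50000 nM in this assay, at which 1 of the 4 values shown sits.

As far as these compounds go, whether a morpholine ring or a piperazine without its methyl group would track compound 3 or compound 4 stays open. So does the effect of a longer chain carrying 4-methylpiperazin-1-yl.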